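Acetoxypropyl for Hydroxyethyl on a Quinone Side Chain

The compounds below may be only part of what the source reports. "The series", "measured", "known", "first", "only" and "open" are said of these compounds alone.

Compound 1 `CC(C)=CC[C@@H](OC[C@H](C)O)C1=CC(=O)c2c(O)ccc(O)c2C1=O` and compound 2 `COCCO[C@H](CC=C(C)C)C1=CC(=O)c2c(O)ccc(O)c2C1=O` share the same core and are both tested in a functional assay on HeLa cells (Homo sapiens) for cytotoxicity, read by MTT assay; on this read-out lower numbers stand for stronger inhibition and higher numbers for weaker inhibition. In this assay compound 1 gives 40300 nM, the lowest of the two numbers, and compound 2 gives 62400 nM. Among the compounds with values here, the only measured step, a 1.5-fold higher number from compound 1 to compound 2 (0.19 log units; within the scatter), swaps one small oxygen-bearing group for another on the side chain and stays within the scatter.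

Compound 3 `CCC(CO[C@H](CC=C(C)C)C1=CC(=O)c2c(O)ccc(O)c2C1=O)OC(C)=O` differs from compound 1 by 1-acetoxypropyl in place of 1-hydroxyethyl on a saturated chain carbon bound to an oxygen on a saturated carbon. The step to compound 2 is the only one that bears on it, and it was small; the entering group removes the single donor and is larger, so an account with confidence beyond that is not supported by the data shown. Compound 3 is therefore expected to give a number close to compound 1, a 1.4-fold higher number from compound 1 to compound 3 (0.14 log units; within the scatter), with an estimate of 55000 nM in this assay, ranging from 25000 nM to 120000 nM.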

Compound 3, half-maximal inhibitory concentration: 44000 nM
The estimate for compound 3 lay 1.3-fold (0.10 log units) above the measured number; the range from low to high includes it.
By their numbers in this assay, from the lowest: compounds 1, 3 and 2 (each within the scatter of the next).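

In this assay the change to 1-acetoxypropyl (a 1.1-fold higher number from compound 1 to compound 3 (0.04 log units; within the scatter)) shows that this place, on a saturated chain carbon bound to an oxygen on a saturated carbon, accepts a group of 7 heavy atoms with 0 hydrogen-bond donors in place of 1-hydroxyethyl with no step beyond the scatter. The comparison with the methoxymethyl side of the series (a 1.4-fold lower number from compound 2 to compound 3 (0.15 log units; within the scatter)) also stays within the scatter. All three compounds therefore lie within the scatter of one another, so neither the hydroxyl of compound 1 nor the size of the entering group is tied to any measurable difference here.

Going by these compounds, whether an amine, a carboxylic acid or a longer unbranched alkyl chain at this place would leave the same band of values remains open. Nothing shown gives a measured reason for the closeness of these values.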